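This account rests on a few compounds, and the source may have more. Where it says the series, first, only, none or still open, it means among the compounds named here.

Two sulfonamides share a core built from a bis(trifluoromethyl)phenyl sulfonyl group linked through a short chain to an amine bearing a benzyl substituent. Compound 1 `CC(C)(C)c1ccc(CNCCCNS(=O)(=O)c2cc(C(F)(F)F)cc(C(F)(F)F)c2)cc1` carries a 4-(tert-butyl)benzyl group on a three-carbon chain, and compound 2 `O=S(=O)(NCCNCc1ccc(-c2ccccc2)cc1)c1cc(C(F)(F)F)cc(C(F)(F)F)c1` carries a biphenylmethyl group on a two-carbon chain. In a functional assay on ASPC1 cells (Homo sapiens) for inhibition, read by MTT assay, with a stated time of 72 h (on this read-out lower numbers stand for stronger inhibition of growth and higher numbers for weaker inhibition of growth), compound 1 gives 2700 nM, and compound 2 gives 2800 nM; the two numbers sit within the usual scatter of each other, so neither compound can be called stronger on this evidence.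

Compound 3 `O=S(=O)(NCCCNCc1ccc(Cl)c(Cl)c1)c1cc(C(F)(F)F)cc(C(F)(F)F)c1` keeps the three-carbon chain of compound 1 and changes only the aryl group: 3,4-dichlorophenyl in place of 4-(tert-butyl)phenyl on a saturated chain carbon bound to an amine nitrogen. Going by the values given here, no measured pair shows what such a swap does here, so any expectation rests on the closeness of the two numbers seen so far. The step from compound 1 to compound 3 is expected to be small, a 1.3-fold higher number from compound 1 to compound 3 (0.11 log units; within the scatter), in either direction or none beyond the scatter. For compound 3 in this assay the estimate is 3500 nM, with a likely range from 1500 nM to 9000 nM.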

Compound 3, concentration for 50% growth inhibition: 2800 nM
The estimate for compound 3 lay 1.3-fold (0.10 log units) above the measured number, and the stated range covers the measured number.
By their numbers in this assay, from the lowest: compounds 1, 2 and 3 (each within the scatter of the next).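

Putting 3,4-dichlorophenyl in place of 4-(tert-butyl)phenyl on a saturated chain carbon bound to an amine nitrogen gives a 1.0-fold higher number from compound 1 to compound 3 (0.02 log units; within the scatter) in this assay. This is the first pair shown that differs in one place only, and it shows that these two aryl groups, one of 10 carbon atoms and the other of 6 carbon and 2 chlorine atoms, cannot be told apart on this read-out. No measurement at hand accounts for this result.

Compound 2 differs from compound 1 and compound 3 in both its chain and its aryl group, so the contribution of each of those two parts remains unresolved. On these data alone, it also remains open whether a carboxylic acid or an amine on the aryl ring, or a longer chain, would move the number beyond the scatter.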